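The source may report more compounds than this note shows. Statements on the series, on what has been measured and on what is new or still open speak of the compounds shown alone.

In a functional assay on A549 cells (Homo sapiens) for inhibition, read by CCK-8 assay, with a stated time of 72 h, tested at 2 uM (on this read-out higher numbers stand for more inhibition of growth at the one concentration tested and lower numbers for less inhibition of growth), compound 1 `Cc1ccc(SCc2ccc(C(=O)Nc3ccccc3N)cc2)cc1` gives 40.5%. Compound 2 `Nc1ccccc1NC(=O)/C=C/c1ccc(CSCCc2ccccc2)cc1` gives 45.7%, within the scatter of compound 1. Compound 3 `COc1ccc(SCc2ccc(C(=O)Nc3ccccc3N)cc2)cc1OC` gives 19.9%, which lies lower than compound 1 by more than the scatter. Compound 4 `Nc1ccccc1NC(=O)c1ccc(CSc2ccc(F)cc2)cc1` departs from compound 1 in one place: fluoro in place of methyl on an aromatic carbon, para to a large group. Within the data shown here, no measured pair shows this change on its own, so the data offer no direct guide to its size. In this assay, no step beyond the scatter is expected, and the estimated change is a number 2.5 percentage points lower from compound 1 to compound 4 (within the scatter). For compound 4 the expected value is 38%, with an estimated range of 22% to 54%.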

Compound 4, percent growth inhibition at one concentration: 43.4%
The estimate for compound 4 lay 5.4 percentage points below the measured number; measured number inside the range.
By their numbers in this assay, from the lowest: compound 3; then compounds 1, 4 and 2 (each within the scatter of the next).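

In this assay, among these compounds, the change of fluoro in place of methyl on an aromatic carbon, para to a large group, gives a number 2.9 percentage points higher from compound 1 to compound 4 (within the scatter) and is the first direct reading of this change here. At this position, going from 4-methylphenyl to 4-fluorophenyl therefore leaves growth inhibition at the one concentration tested within the scatter. Nothing available explains this result.

As far as these compounds go, whether chloro, trifluoromethyl or an amine would be tolerated at this position stays open. So does whether the same change would give a similar step in the core of compound 2.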